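The source may hold more compounds than are shown below. What is called first, only, known or untested is meant among the compounds shown, and "the series" means these compounds.

Compound 1 `O=S(=O)(Nc1cc(-c2cnc3[nH]cc(-c4ccncc4)c3c2)cnc1Cl)c1ccccc1F` gives 3 nM in an assay on isolated protein for inhibition of phosphatidylinositol 4,5-bisphosphate 3-kinase catalytic subunit beta isoform (Homo sapiens), read by luminescence and ADP-Glo, with a stated time of 1 h; a higher number here means a weaker inhibitor, a lower number a stronger inhibitor. Compound 2 `O=S(=O)(Nc1cc(-c2cnc3[nH]cc(-c4ccccc4)c3c2)cnc1Cl)c1ccccc1` gives 39 nM. Compound 3 `O=S(=O)(Nc1cc(-c2cnc3[nH]cc(-c4ccncc4)c3c2)cnc1Cl)c1ccc(F)cc1` gives 2 nM.

Compound 3 has the lowest number of the three, though compound 1 sits within the scatter of it; only compound 2 lies clearly apart. Compound 4 `O=S(=O)(Nc1cc(-c2cnc3[nH]cc(-c4ccncc4)c3c2)cnc1Cl)c1ccccc1` differs from compound 3 by hydrogen in place of fluoro on an aromatic carbon. Within the data shown here, the one measured step that bears on this is a 1.5-fold lower number from compound 1 to compound 3 (0.18 log units; within the scatter), which moved the fluorine about the ring without a shift beyond the scatter; no measured pair removes it outright. Compound 2 also carries a plain phenyl on the sulfonyl sulfur, but it differs from compound 4 elsewhere, so its value gives no direct guide. Compound 4 is therefore expected to show a 2.0-fold higher number from compound 3 to compound 4 (0.30 log units; within the scatter). The estimate for compound 4 in this assay is 4 nM, within 1.5 nM to 12 nM.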

Compound 4, half-maximal inhibitory concentration: 2 nM
The estimate for compound 4 lay 2.0-fold (0.30 log units) above the measured number; the measured number falls inside the stated range.
By their numbers in this assay, from the lowest: compounds 3, 4 and 1 (each within the scatter of the next); then compound 2.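

In this assay the step of no change at the digits printed from compound 3 to compound 4 (within the scatter) and the step of a 1.5-fold lower number from compound 1 to compound 4 (0.18 log units; within the scatter) both remove the fluoro, so the ring on the sulfonyl sulfur needs no fluoro at either place to stay at this level. The step of a 20-fold lower number from compound 2 to compound 4 (1.29 log units; beyond the scatter) is the only one of these beyond the scatter, and it shows pyridin-4-yl in place of phenyl as a single change, with phenylsulfonyl on both sides. No measurement given here accounts for either result.

As far as these compounds go, it stays open whether a methoxy group or an amine on the phenyl ring of the phenylsulfonyl would keep this level. From the compounds shown here alone, it also stays open whether pyridin-3-yl in place of pyridin-4-yl would hold the lower number.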